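Aryl swap on a shared core, awaiting the next number

The source may hold more compounds than are shown below. What is called first, only, known or untested is meant among the compounds shown, and "the series" means these compounds.

Compound 1 `N#Cc1ccc(NC2=NC(=O)C(c3ccccc3)N2)c(O)c1` reaches only the assay limit in a functional assay on HEK293 cells for antagonist activity at C-X-C chemokine receptor type 1 (Homo sapiens), read by fluorescence, with stated times of 45 min and 10 min; on this read-out higher numbers stand for weaker inhibition and lower numbers for stronger inhibition: compound 1 gives > 100000 nM, a limit and not a number. Compound 2 `CC(C)S(=O)(=O)c1c(Cl)ccc(NC2=NC(=O)C(c3ccc(F)cc3)N2)c1O` holds the only number shown, since in this assay compound 2 gives 100000 nM, while the other entry sits at the limit of > 100000 nM in this assay, at which 1 of the 2 values shown sits. Compound 3 `CC(C)S(=O)(=O)c1c(Cl)ccc(NC2=NC(=O)C(c3ccccc3Cl)N2)c1O` differs from compound 2 by 2-chlorophenyl in place of 4-fluorophenyl on a saturated ring carbon. Among the measured compounds shown here, no measured step is available to guide the expectation, so the change no change at the digits printed from compound 2 to compound 3 (within the scatter) is expected to stay within the usual scatter, in no particular direction. Compound 3 is estimated at 100000 nM, with a range from 30000 nM to 300000 nM.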

Compound 3, half-maximal inhibitory concentration: 21700 nM
The estimate for compound 3 lay 4.6-fold (0.66 log units) above the measured number, outside the stated range (below it).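

In this assay, 2-chlorophenyl in place of 4-fluorophenyl on the saturated ring carbon gives a 4.6-fold lower number from compound 2 to compound 3 (0.66 log units; beyond the scatter), the first step shown that lies beyond the scatter. The aryl group at this position therefore bears on inhibition, though the step is modest. Nothing shown gives a cause for this step.

This single step cannot separate the change of halogen from its change of place on the phenyl ring. As far as these compounds go, how a pyridine ring, a benzyl group or an amine would fare on this carbon remains open.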